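Taking the Methyl off the Methoxy: Compound 2 to Compound 4

The compounds below may be only part of what the source reports. "The series", "measured", "known", "first", "only" and "open" are said of these compounds alone.

Measured so far:
Compound 1 `COc1cc(C)cc(-c2c(-c3ccnc(-c4ccc(N(C)C)cc4)c3)cnn2CC#N)c1` — in a functional assay on MDA-MB-468 cells (Homo sapiens) for inhibition, read by sulforhodamine B assay, with a stated time of 48 h (a lower number here means a stronger inhibitor of growth, a higher number a weaker inhibitor of growth), compound 1 gives 26.1 nM.
Compound 2 `COc1cc(C)cc(-c2nn(CC#N)cc2-c2ccnc(-c3ccc(N(C)C)cc3)c2)c1` — in this assay compound 2 gives 181 nM.
Compound 3 `COc1cc(C)cc(-c2nn(CC#N)cc2-c2ccc(-c3cccc(C(C)=O)c3)nc2)c1` — in this assay compound 3 gives 275 nM.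

Of the three numbers, compound 2 sits at the second highest. Its nearest neighbour is compound 3, and the gap between the two lies within the usual scatter of repeated measurements, so nothing can be said about which of them is the stronger inhibitor. Compound 1 is furthest away, with a clearly lower number that lies beyond the scatter, and so it inhibits growth more strongly than compound 2.

Compound 4 `Cc1cc(O)cc(-c2nn(CC#N)cc2-c2ccnc(-c3ccc(N(C)C)cc3)c2)c1` has not yet been measured. It differs from compound 2 in one place only: hydrogen in place of methyl on an oxygen on an aromatic ring. Among the compounds with values here, no measured pair shows this particular change, so there is no directly comparable step to lean on.

Without such a reference, the expectation is cautious. In this assay compound 4 is expected to land close to compound 2, with a step of a 1.1-fold higher number from compound 2 to compound 4 (0.04 log units; within the scatter) that is expected to stay within the scatter, in no firm direction. The estimate for compound 4 is therefore 200 nM, with a plausible range from 60 nM to 650 nM.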

Compound 4, concentration for 50% growth inhibition: 1630 nM
Compound 4: the middle estimate sits 8.2-fold (0.91 log units) below what was measured, outside the stated range (above it).
By their numbers in this assay, from the lowest: compound 1; then compounds 2 and 3 (each within the scatter of the next); then compound 4.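

In this assay, within the data shown here, the only change is methoxy to hydroxy, and it produces a 9.0-fold higher number from compound 2 to compound 4 (0.95 log units; beyond the scatter). This step shows that the group on this oxygen on an aromatic ring matters for growth inhibition, since losing a single methyl carbon leaves compound 4 a clearly weaker inhibitor than compound 2. Compounds 1, 2 and 3 all carry the methoxy group, so they could say nothing about this position, and nothing measured here accounts for the size of the step.

The compounds shown leave open how a longer chain on the same oxygen, such as ethoxy, or an amine in place of the methoxy group would compare with the methoxy and hydroxy groups. They also leave open whether the same change from methoxy to hydroxy would cost as much in compound 1 or compound 3, as this single pair cannot show whether the loss holds beyond the 3-methoxy-5-methylphenyl group of compound 2 and the rest of its structure.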